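The source may hold more compounds than are shown below. What is called first, only, known or untested is meant among the compounds shown, and "the series" means these compounds.

Working notes on the series. Among the compounds with values here, in an ADME assay on microsomes from liver (Mus musculus) for metabolic stability, read by LC-MS, with a stated time of 30 min, tested at 1 uM (on this read-out higher numbers stand for a more stable compound and lower numbers for a less stable compound), compound 2 (`O=C(NCc1ccc(S(=O)(=O)N2CCCCC2)cc1)c1cnc2nccn2c1`) gives 0.28%, the only number available so far. Compound 1 (`O=C(NCc1ccc(S(=O)(=O)N2CCCCC2)cc1)c1cc2ccncc2[nH]1`) gives "below limit of detection" (no number reported). Within the data shown here, with only one number, compound 2 cannot yet be ranked on a numerical scale.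

Compound 3 (`O=C(NCc1ccc(S(=O)(=O)N2CCCCC2)cc1)c1ccc2nc[nH]c2c1`) is still to be measured in this assay. It keeps the rest of compound 2 and alters only the group on the carbonyl carbon: a group of 9 heavy atoms (7 carbon, 2 nitrogen; one five-membered aromatic ring with 2 hetero atoms, one six-membered aromatic ring of carbon only) in place of a group of 9 heavy atoms (6 carbon, 3 nitrogen; one five-membered aromatic ring with 2 hetero atoms, one six-membered aromatic ring with 2 hetero atoms), on a carbonyl carbon. Among the measured compounds shown here, no measured step between compounds is available as a guide. The expectation is therefore no step beyond the usual scatter, with any movement running upward because compound 2 at 0.28% leaves little room lower. The expected change is a number 1.7 percentage points higher from compound 2 to compound 3 (within the scatter). For compound 3, the estimate is 2%, with an expected range of 0% to 12%.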

Compound 3, percent of the compound remaining: 16%
For compound 3 the middle estimate is 14 percentage points below the measured one; the whole stated range lies below it.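

In this assay, within the data shown here, putting 1H-benzimidazol-6-yl on the carbonyl carbon, with the rest of the molecule unchanged, gives a number 15.7 percentage points higher from compound 2 to compound 3 (beyond the scatter) and this is the first step that can be read. Both groups have 9 heavy atoms, but the entering group has a six-membered aromatic ring of carbon only and 1 hydrogen-bond donor, while the leaving group has a six-membered aromatic ring with 2 hetero atoms and 0 hydrogen-bond donors, so this position responds to a change that keeps the heavy-atom count. No supporting data bear on what lies behind the step.

The compounds shown do not separate the change in ring atoms from the gain of the hydrogen-bond donor. On these data alone, the effect of a methyl group on the hydrogen-bearing nitrogen of 1H-benzimidazol-6-yl also stays open.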